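A few compounds are considered here, and "the series" means these few. Any claim that something is new, unique, unknown or untested is made for them only; others in the source may bear on it.

Measured compounds:
Compound 1 `CCCCCCC#Cc1cn(C/C=C/CN2C(=O)c3ccccc3C2=O)c(=O)[nH]c1=O` – 30000 nM
Compound 2 `CCCCCC#Cc1cn(C/C=C/CN2C(=O)c3ccccc3C2=O)c(=O)[nH]c1=O` – 60000 nM

Both numbers come from a functional assay on MIA PaCa-2 cells (Homo sapiens) for antiproliferative activity, read by MTT assay, with a stated time of 3 days (a higher number here means a weaker inhibitor, a lower number a stronger inhibitor), in which compound 1 gives 30000 nM and compound 2 gives 60000 nM. For the measured compounds named here, compound 2 carries the highest of the two numbers, and its nearest neighbour is compound 1; the step of a 2.0-fold higher number from compound 1 to compound 2 (0.30 log units; within the scatter) is the only measured step, and it lies within the scatter.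

Compound 3 `CCCCCc1ccc(C#Cc2cn(C/C=C/CN3C(=O)c4ccccc4C3=O)c(=O)[nH]c2=O)cc1` is the next compound in the series. It differs from compound 2 in one place: 4-pentylphenyl in place of pentyl on a triple-bonded carbon. Going by the values given here, no measured step bears directly on this change, since the one step that exists, from compound 1 to compound 2, concerns only the length of the chain and was itself within the scatter. The step from compound 2 to compound 3 is therefore expected to be modest, with the estimated value for compound 3 being a 2.0-fold lower number from compound 2 to compound 3 (0.30 log units; within the scatter). Compound 3 is expected to give 30000 nM in this assay, with a range from 8000 nM to 100000 nM.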

Compound 3, half-maximal inhibitory concentration: 26000 nM
Estimate against measurement, compound 3: 1.2-fold (0.06 log units) above, and the stated range covers the measured number.
By their numbers in this assay, from the lowest: compounds 3, 1 and 2 (each within the scatter of the next, the first and the last beyond it).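

Working notes on the triple-bonded carbon: in this assay the change from pentyl to 4-pentylphenyl gives a 2.3-fold lower number from compound 2 to compound 3 (0.36 log units; beyond the scatter) and is the first step in the series to lie beyond the scatter, so this carbon tolerates a six-membered aromatic ring of carbon only without any loss. Set against hexyl, the same group gives a 1.2-fold lower number from compound 1 to compound 3 (0.06 log units; within the scatter) and lies within the scatter, so the difference from pentyl does not separate 4-pentylphenyl from hexyl, and any benefit of the ring over a plain chain remains unshown. No available evidence accounts for either step.

The compounds shown leave open whether the ring or its pentyl chain carries the step from the pentyl compound. As far as these compounds go, how an unsubstituted phenyl, or a chain ending in an amine or a carboxylic acid, would read at this carbon also remains open.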